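Trading a Phenyl for a Short Diene Chain

The source may report more compounds than this note shows. Statements on the series, on what has been measured and on what is new or still open speak of the compounds shown alone.

Among the measured compounds shown here, compound 2 `CCCCCCCCCCCCCCNC(=O)[C@@H](NC(=O)/C=C/c1ccccc1)[C@@H](C)O` gives, in a functional assay on MCF7 cells (Homo sapiens) for cytotoxicity, read by MTT assay, with a stated time of 48 h (on this read-out higher numbers stand for weaker inhibition and lower numbers for stronger inhibition), a value of 64600 nM, which is the higher of the two numbers measured so far. For the measured compounds named here, its only neighbour, compound 1 `CCCCCCCCCCCCCCNC(=O)[C@@H](NC(=O)c1cc2ccccc2o1)[C@@H](C)O`, gives 23400 nM in this assay. Going by the values given here, the single measured step, a 2.8-fold higher number from compound 1 to compound 2 (0.44 log units; beyond the scatter), shows that the earlier change on the carbonyl carbon already pushed the number upward, meaning weaker inhibition. Compound 3 `C/C=C/C=C/C(=O)N[C@H](C(=O)NCCCCCCCCCCCCCC)[C@@H](C)O` carries the change (prop-1-en-1-yl in place of phenyl on a double-bonded chain carbon bound to a double-bonded chain carbon); the double bond stays, but the aromatic ring is gone. Among the compounds with values here, no measured step tests a change of this kind directly, so the step from compound 1 to compound 2 is only a distant guide. Because a 2.8-fold higher number from compound 1 to compound 2 (0.44 log units; beyond the scatter) went upward, a further modest rise in the number is expected for compound 3, a 1.4-fold higher number from compound 2 to compound 3 (0.14 log units; within the scatter). Compound 3 is therefore estimated at 90000 nM, within a range of 30000 nM to 250000 nM.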

Compound 3, half-maximal inhibitory concentration: 27800 nM
Compound 3: the middle estimate sits 3.2-fold (0.51 log units) above what was measured; measured number outside the range, below it.
By their numbers in this assay, from the lowest: compounds 1 and 3 (each within the scatter of the next); then compound 2.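

Removing the aromatic ring costs nothing in this assay: prop-1-en-1-yl in place of phenyl gives a step in the favourable direction (a 2.3-fold lower number from compound 2 to compound 3 (0.37 log units; beyond the scatter)), so for these two compounds the phenyl is not needed at this place. The open-chain penta-1,3-dien-1-yl also cannot be told apart from the 1-benzofuran-2-yl group on the carbonyl carbon (a 1.2-fold higher number from compound 1 to compound 3 (0.07 log units; within the scatter)), so an aromatic group is not required there to reach this level of activity. Nothing available explains why the chain does better than the phenyl.

Going by these compounds, it remains open whether a saturated pentyl chain in place of penta-1,3-dien-1-yl would hold the number, which would show whether the double bonds matter at all. Also open, on these data alone, is what a chain carrying a carboxylic acid or an amine would do.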